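Replacing the aromatic arm: from compound 3 to compound 4

A few compounds are considered here, and "the series" means these few. Any claim that something is new, unique, unknown or untested is made for them only; others in the source may bear on it.

Three measured compounds share one core and differ only in a group on an outer aromatic ring. In an in vitro assay on CHOK cells for displacement of a labelled ligand from growth hormone secretagogue receptor type 1 (Homo sapiens) (a lower number here means a stronger inhibitor, a higher number a weaker inhibitor), compound 1 `Nc1nc(N)c(-c2ccc(NCc3ccc([N+](=O)[O-])cc3)cc2)c(COCc2ccccc2)n1` gives 0.2 nM, compound 2 `N#Cc1ccc(CNc2ccc(-c3c(N)nc(N)nc3COCc3ccccc3)cc2)cc1` gives 2.8 nM, and compound 3 `COc1ccc(CNc2ccc(-c3c(N)nc(N)nc3COCc3ccccc3)cc2)cc1` gives 7.7 nM, the highest number of the three. The steps of a 14-fold higher number from compound 1 to compound 2 (1.15 log units; beyond the scatter), a 39-fold higher number from compound 1 to compound 3 (1.59 log units; beyond the scatter) and a 2.8-fold higher number from compound 2 to compound 3 (0.44 log units; beyond the scatter) all keep that ring and swap only what sits on it. Compound 4 `CC(C)(C)CNc1ccc(-c2c(N)nc(N)nc2COCc2ccccc2)cc1` goes further: tert-butyl in place of 4-methoxyphenyl on a saturated chain carbon bound to a nitrogen on an aromatic ring. Among the compounds with values here, no measured step removes the ring, so nothing directly bears on this change; every move away from compound 1 so far has weakened binding. A further weakening is expected, a 3.9-fold higher number from compound 3 to compound 4 (0.59 log units; beyond the scatter). Compound 4 is therefore estimated at 30 nM in this assay, between 5 nM and 200 nM.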

Compound 4, half-maximal inhibitory concentration: 67 nM
Estimate against measurement, compound 4: 2.2-fold (0.35 log units) below; low and high end bracket the measured number.
By their numbers in this assay, from the lowest: compound 1; then compound 2; then compound 3; then compound 4.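

Within the data shown here, compound 4 is the first compound here without an aromatic ring on this chain carbon, and in this assay tert-butyl gives weaker binding than each ring-bearing group: an 8.7-fold higher number from compound 3 to compound 4 (0.94 log units; beyond the scatter) and a 24-fold higher number from compound 2 to compound 4 (1.38 log units; beyond the scatter) and a 340-fold higher number from compound 1 to compound 4 (2.53 log units; beyond the scatter) mark the cost. The ring is therefore not needed for measurable binding, but all three compounds that carry it bind more strongly. Nothing available explains this loss. Still open, on these data alone, is whether an unsubstituted phenyl or a saturated cyclohexyl group would stand closer to compound 3 or to compound 4.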